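A few compounds are considered here, and "the series" means these few. Any claim that something is new, unique, unknown or untested is made for them only; others in the source may bear on it.

Measured so far in a functional assay (aorta) with Rattus norvegicus as the target; a lower number here means a stronger inhibitor, a higher number a weaker inhibitor:
- compound 1 `CC1(C)Oc2ccc(C#N)cc2[C@@H](/N=C(\NC#N)Sc2ccccc2)[C@@H]1O` gives 4900 nM
- compound 2 `CC1(C)Oc2ccc(C#N)cc2[C@@H](/N=C(\NC#N)Nc2cccc(C(=O)O)c2)[C@@H]1O` gives > 100000 nM (a limit)

For compound 2 the reading > 100000 nM is a limit of the assay and not a number, so no exact starting point exists for the next step. Compound 3 `CSc1ccc(N/C(=N/[C@@H]2c3cc(C#N)ccc3OC(C)(C)[C@H]2O)NC#N)cc1` carries the change (4-(methylsulfanyl)phenyl in place of 3-carboxyphenyl on an amine nitrogen), with 4-(methylsulfanyl)phenyl in place of 3-carboxyphenyl on an amine nitrogen. Among the measured compounds shown here, one measured step bears on this, the large rise an at least 20-fold higher number from compound 1 to compound 2 (1.30 log units; beyond the scatter), which brought in the 3-carboxyphenyl group that now leaves. Compound 3 drops that group but keeps the amine nitrogen, so a large move to a lower number is expected in this assay, towards compound 1 at 4900 nM but resting on that single step. The expected change is an at least 25-fold lower number from compound 2 to compound 3 (1.39 log units; beyond the scatter) in the estimate used here. For compound 3 the estimated value is 4000 nM, with an expected range from 700 nM to 30000 nM.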

Compound 3, half-maximal inhibitory concentration: 6300 nM
Estimate against measurement, compound 3: 1.6-fold (0.20 log units) below; measured number inside the range.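

In this assay, 4-(methylsulfanyl)phenyl in place of 3-carboxyphenyl on the amine nitrogen gives an at least 15-fold lower number from compound 2 to compound 3 (1.20 log units; beyond the scatter), so the amine nitrogen alone does not account for the earlier loss. The value of compound 2 is a limit and not a number: the limit of > 100000 nM in this assay, at which 1 of the 3 values shown sits. The other new comparison, (4-(methylsulfanyl)phenyl)amino in place of phenylsulfanyl, gives a 1.3-fold higher number from compound 1 to compound 3 (0.11 log units; within the scatter), so these two groups cannot be told apart at this position in this assay.

The change from compound 2 to compound 3 alters both the substituent and its place on the phenyl ring, so the compounds shown do not separate these two factors. Also open, from the compounds shown here alone, is how a plain phenyl on the amine nitrogen, or a methyl ester or primary amide in place of the carboxylic acid, would read in this assay.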